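Swapping fluorine for chlorine on the outer phenoxy ring

This account rests on a few compounds, and the source may have more. Where it says the series, first, only, none or still open, it means among the compounds named here.

Measured so far:
compound 1, `CC(Oc1ccc(Oc2ccc(Cl)cc2)cc1)C(=O)Cn1nnc(-c2ccccc2)n1`, 6
compound 2, `CCCCCCCCc1ccc(OC(C)C(=O)Cn2nnc(-c3ccc(C(=O)OC)cc3)n2)cc1`, > 8
compound 3, `COC(=O)c1ccc(-c2nnn(CC(=O)C(C)Oc3ccc(Oc4ccc(F)cc4)cc3)n2)cc1`, 5.4

In a physicochemical assay for lipophilicity, read by HPLC, tested at 5 mM (a lower number here means a more polar compound, a higher number a more lipophilic compound), compound 3 gives 5.4, the lowest of the two plain numbers. Compound 1 sits higher, at 6, a gap beyond the scatter; compound 1 and compound 3 differ in two places, so their values are only compared here, not traced to one change. The value of compound 2 is a limit of this assay, not a number (the limit of > 8 in this assay, at which 1 of the 3 values shown sits).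

Compound 4, `COC(=O)c1ccc(-c2nnn(CC(=O)C(C)Oc3ccc(Oc4ccc(Cl)cc4)cc3)n2)cc1`, is to be measured in this assay. It differs from compound 3 by chloro in place of fluoro on an aromatic carbon. Among the compounds with values here, the only measured step, a number at least 2.60 log units lower from compound 2 to compound 3 (beyond the scatter), replaces a whole octyl chain and says little about a one-atom halogen swap; it only shows how far this assay can move. Chloro in place of fluoro is a small change, so a modest rise is expected: a number 0.60 log units higher from compound 3 to compound 4 (beyond the scatter). Compound 4 is therefore expected to give 6, between 5.5 and 6.5.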

Compound 4, partition coefficient: 6.1
Compound 4: the middle estimate sits 0.10 log units below what was measured, and the stated range covers the measured number.
By their numbers in this assay, from the lowest: compound 3; then compounds 1 and 4 (each within the scatter of the next). At a limit, above all of these: compound 2.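

In this assay, the halogen on the outer phenoxy ring has a measurable effect of its own: chloro in place of fluoro gives a number 0.70 log units higher from compound 3 to compound 4 (beyond the scatter), the only step shown that changes nothing but this halogen. Methoxycarbonyl in place of hydrogen gives a number 0.10 log units higher from compound 1 to compound 4 (within the scatter), so of the two places where compound 1 and compound 3 differ, only the halogen carries a step beyond the scatter. Putting 4-chlorophenoxy in place of octyl gives a number at least 1.90 log units lower from compound 2 to compound 4 (beyond the scatter), a step read from a limit and not from a number: the limit of > 8 in this assay, at which 1 of the 4 values shown sits.

The compounds shown leave open how bromo, methoxy or an amine on this aromatic carbon would read in this assay. They also leave open whether chloro in place of fluoro gives the same step on the core of compound 1, which carries hydrogen where compound 4 carries methoxycarbonyl.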